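A ring swap on compound 1

This account rests on a few compounds, and the source may have more. Where it says the series, first, only, none or still open, it means among the compounds named here.

Measured compounds:
compound 1 (`COc1ccc(-c2cc(NC(=O)Nc3ccncc3)cc(C(F)(F)F)c2)cn1`) 276000 nM
compound 2 (`COc1ccc(-c2cc(NC(=O)Nc3nccs3)cc(C(F)(F)F)c2)cn1`) "not determined" (no result reported)

For the measured compounds named here, in a functional assay on A549 cells (Homo sapiens) for inhibition, read by MTT assay, with a stated time of 48 h (on this read-out lower numbers stand for stronger inhibition and higher numbers for weaker inhibition), compound 1 gives 276000 nM and this is the only number available, as compound 2 has no reported result. Compound 1 therefore cannot be ranked against any neighbour. It stands alone, with a high number that on this read-out means weak inhibition.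

Compound 3 (`Cn1cnc(-c2cc(NC(=O)Nc3ccncc3)cc(C(F)(F)F)c2)c1`) keeps the rest of compound 1 and changes one group. It carries 1-methyl-1H-imidazol-4-yl in place of 6-methoxypyridin-3-yl on an aromatic carbon, meta to a trifluoromethyl group (1-methyl-1H-imidazol-4-yl in place of 6-methoxypyridin-3-yl on an aromatic carbon). Going by the values given here, no pair of measured compounds shows what an exchange of this kind does. With compound 1 at 276000 nM as the lone reference, nothing favours a direction, so no change beyond the usual scatter is expected, though with wide uncertainty. The expected move is a 1.1-fold lower number from compound 1 to compound 3 (0.04 log units; within the scatter) in this assay on this reasoning. A report without a number, as for compound 2, also remains possible. Compound 3 is estimated at 250000 nM with an expected range of 60000 nM to 600000 nM once it is measured.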

Compound 3, half-maximal inhibitory concentration: 39400 nM
The estimate for compound 3 lay 6.3-fold (0.80 log units) above the measured number; measured number outside the range, below it.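

In this assay, for the compounds shown here, the exchange of 6-methoxypyridin-3-yl for 1-methyl-1H-imidazol-4-yl gives a 7.0-fold lower number from compound 1 to compound 3 (0.85 log units; beyond the scatter), which is the first readable step in this set and shows that the group on this aromatic carbon, meta to a trifluoromethyl group, can move the read-out beyond the usual scatter. Going by these compounds alone, the single step changes several things at once: a six-membered aromatic ring with 1 hetero atom gives way to a five-membered aromatic ring with 2 hetero atoms, and the methoxy group leaves while a methyl group enters, so the share of each change in the lower number cannot be separated. No measurement is available that bears on why the number falls.

The compounds shown leave open whether a plain phenyl ring, an unsubstituted pyridin-3-yl, or a group of another kind, such as an amine or a carboxylic acid, would take the number further in either direction from that of compound 3 at 39400 nM. They also leave open whether the same exchange would give a similar step with a thiazol-2-yl group in place of the pyridin-4-yl group at the far end of the shared core.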